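Carbonyl to sulfonyl on a shared core

The compounds below may be only part of what the source reports. "The series", "measured", "known", "first", "only" and "open" are said of these compounds alone.

Of the compounds shown here, three with a shared core have been measured in a functional assay on K562 cells (Homo sapiens) for cytotoxicity, read by MTT assay (a lower number here means a stronger inhibitor, a higher number a weaker inhibitor), and they differ only in the group on an oxygen on an aromatic ring. Compound 1 `COc1ccc(/C=C/C(=O)c2ccc(OC)c3c2OC(C)(C)C=C3)cc1OCCCN(C)C` gives the highest number (2920 nM) and compound 2 `COc1ccc(/C=C/C(=O)c2ccc(OC)c3c2OC(C)(C)C=C3)cc1OC(=O)C(C)C` a lower one (570 nM). Compound 3 `COc1cccc(C(=O)Oc2cc(/C=C/C(=O)c3ccc(OC)c4c3OC(C)(C)C=C4)ccc2OC)c1` (790 nM) lies clearly under compound 1 and within the scatter of compound 2.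

Compound 4 `COc1ccc(/C=C/C(=O)c2ccc(OC)c3c2OC(C)(C)C=C3)cc1OS(=O)(=O)c1ccc(C)cc1` has no number yet. For the measured compounds named here, it keeps the core and changes only that group ((4-methylphenyl)sulfonyl in place of (3-methoxyphenyl)carbonyl on an oxygen on an aromatic ring) so (4-methylphenyl)sulfonyl stands in place of (3-methoxyphenyl)carbonyl.

Two modest steps show that this oxygen's group can matter: a 5.1-fold lower number from compound 1 to compound 2 (0.71 log units; beyond the scatter) and a 3.7-fold lower number from compound 1 to compound 3 (0.57 log units; beyond the scatter) both came from removing 3-(dimethylamino)propyl. The closer comparison is a swap between groups on a carbonyl carbon, where compound 3 replaced the isopropyl of compound 2 and gave only a 1.4-fold higher number from compound 2 to compound 3 (0.14 log units; within the scatter) as its step. Going by the values given here, no measured compound carries a sulfonyl group, so that part of the change is untested and the range must stay wide.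

The expected step is (a 1.0-fold higher number from compound 3 to compound 4 (0.01 log units; within the scatter)) and nothing beyond the scatter is expected. Compound 4 is estimated at 800 nM with an expected range of 300 nM to 2200 nM for now.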

Compound 4, half-maximal inhibitory concentration: 7850 nM
Estimate against measurement, compound 4: 9.8-fold (0.99 log units) below; the whole stated range lies below it.
By their numbers in this assay, from the lowest: compounds 2 and 3 (each within the scatter of the next); then compound 1; then compound 4.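

In this assay, the link on this oxygen turns out to matter far more than the earlier swap between two carbonyl groups suggested: those two groups stayed within the scatter of each other, whereas moving to the sulfonyl group gives a clear loss of activity (a 9.9-fold higher number from compound 3 to compound 4 (1.00 log units; beyond the scatter)) and a larger one against the isopropylcarbonyl group (a 14-fold higher number from compound 2 to compound 4 (1.14 log units; beyond the scatter)). Compound 4 is also weaker than the compound with the 3-(dimethylamino)propyl group (a 2.7-fold higher number from compound 1 to compound 4 (0.43 log units; beyond the scatter)), which makes it the weakest of the four and shows that this oxygen's group can push the number up as well as bring it down. Nothing available here gives a reason for this loss.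

The step to compound 4 changes two things at once, carbonyl to sulfonyl and 3-methoxyphenyl to 4-methylphenyl, so the compounds shown cannot say which of the two accounts for it. A (4-methylphenyl)carbonyl group or a (3-methoxyphenyl)sulfonyl group on this oxygen would separate the two changes, and a methylsulfonyl group would show whether the sulfonyl link gives a high number without an aromatic ring attached.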